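The source may hold more compounds than are shown below. What is called first, only, known or untested is meant among the compounds shown, and "the series" means these compounds.

Measured compounds:
compound 1 `CCc1cc2c(C(=O)c3ccc(OC)cc3)c(OC)ccc2o1` in an assay for inhibition of solute carrier family 22 member 12 (Homo sapiens), read by scintillation counting, with a stated time of 60 min, tested at 50 uM (a lower number here means less inhibition, a higher number more inhibition at the concentration tested (going by the name of the read-out)), gives 6.1%
compound 2 `CCc1oc2cc(OC)ccc2c1C(=O)c1ccc(OC)cc1` gives 6.2%
compound 3 `CCc1cc2c(C(=O)c3ccc(O)cc3)c(OC)ccc2o1` gives 88.2%

Compound 1 stands lowest of the three numbers in this assay. Its nearest neighbour is compound 2, which lies within the scatter of it, so the two cannot be ordered. Compound 3 is the furthest: the step of a number 82.1 percentage points higher from compound 1 to compound 3 (beyond the scatter) is large and well beyond the scatter, and it comes from a single structural change, hydrogen in place of methyl on an oxygen on an aromatic ring, at the oxygen on the benzoyl ring.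

Compound 4 `CCc1cc2c(C(=O)c3ccc(OC)cc3)c(O)ccc2o1` is not yet measured. It differs from compound 1 in one place: hydrogen in place of methyl on an oxygen on an aromatic ring. Among the measured compounds shown here, the change is of the same kind as the one from compound 1 to compound 3, but it sits on the other oxygen, the one on the shared core. For the measured compounds named here, the one measured step that bears on it is therefore only a partial guide: it shows that removing a methyl from an oxygen can raise inhibition greatly, but it gives no reading for this second oxygen. Compound 4 is accordingly expected to lie above compound 1 by a moderate step, a number 33.9 percentage points higher from compound 1 to compound 4 (beyond the scatter), with wide uncertainty. The estimate for compound 4 is 40%, within a range from 8% to 85%.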

Compound 4, a percentage reported as inhibition, at one concentration (the size of the read-out at that concentration, not a potency): 28.7%
Compound 4: middle estimate off by 11.3 percentage points, on the high side; low and high end bracket the measured number.
By their numbers in this assay, from the lowest: compounds 1 and 2 (each within the scatter of the next); then compound 4; then compound 3.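

Methoxy to hydroxy on the oxygen of the shared core also raises the number in this assay, with a number 22.6 percentage points higher from compound 1 to compound 4 (beyond the scatter), so the gain seen on the benzoyl ring is not confined to that one oxygen. The same change does not give the same size of step at both places: it is modest here, whereas a number 82.1 percentage points higher from compound 1 to compound 3 (beyond the scatter) is large, so among these compounds the size of the gain depends on which of the two oxygens carries the hydrogen. Nothing available bears on what lies behind this difference between the two oxygens.

The compounds shown leave open whether a hydroxy on both oxygens at once would add the two gains together, and whether the gain belongs to hydroxy itself or would also appear with an amine or a carboxylic acid in the same place. On these data alone, they also give no reading of the ethyl group on the shared core, so it remains open how a longer chain such as propyl, or a methyl, would behave there.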